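A Furan on the Nitrogen of an Unmeasured Series

The source may report more compounds than this note shows. Statements on the series, on what has been measured and on what is new or still open speak of the compounds shown alone.

In a functional assay on cells (Platelet, Homo sapiens) for inhibition (a higher number here means a weaker inhibitor, a lower number a stronger inhibitor), compound 2 `CCOC(=O)c1ccc(-c2nn(Cc3ccc(F)cc3)c3ccccc23)cc1` gives > 10000 nM, which is a limit. Compound 3 `CCOC(=O)c1ccc(-c2nn(Cc3cccc(OC)c3)c3ccccc23)cc1` gives > 10000 nM, also a limit. Compound 1 `CCOC(=O)c1cccc(-c2n[nH]c3ccccc23)c1` gives > 10000 nM, again a limit. Compound 2 therefore stands with the others at the limit of > 10000 nM in this assay, at which 3 of the 3 values shown sit, and no number is available for any of them. Compound 4 `CCOC(=O)c1ccc(-c2nn(-c3ccoc3)c3ccccc23)cc1` differs from compound 2 by furan-3-yl in place of 4-fluorobenzyl on an aromatic nitrogen. Among the measured compounds shown here, the only measured step that bears on this change is a step that the two limits leave unreadable from compound 2 to compound 3, and it offers neither a size nor a direction. A step that the limit leaves unreadable from compound 2 to compound 4 is expected, though it is only a weak estimate and its direction remains unsupported. For compound 4 the estimated value is 15000 nM, with an expected range from 4000 nM to 50000 nM.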

Compound 4, half-maximal inhibitory concentration: > 10000 nM
Compound 4: only a limit was reported; the forecaster's own chance of this, stated with the estimate: 80%; the middle value does not contradict the limit.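

Compound 4 also gives only a limit in this assay, and its steps from compound 2 and from compound 3 cannot be read. The compounds shown leave open how strongly any of them inhibits: the limit of > 10000 nM in this assay, at which 4 of the 4 values shown sit.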